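A few compounds are considered here, and "the series" means these few. Any claim that something is new, unique, unknown or untested is made for them only; others in the source may bear on it.

In a functional assay on A549 cells (Homo sapiens) for antiproliferative activity, read by MTT assay, with a stated time of 72 h (a lower number here means a stronger inhibitor, a higher number a weaker inhibitor), compound 1 `COc1cc(-n2cnc3ccc(-c4ccccc4)cc32)cc(OC)c1OC` gives 3060 nM and compound 2 `COc1cc(-n2cnc3ccc(-c4ccc(C(F)(F)F)cc4)cc32)cc(OC)c1OC` gives 3390 nM as its reading. Going by the values given here, the only measured step is a 1.1-fold higher number from compound 1 to compound 2 (0.04 log units; within the scatter) and it leaves compound 2 level with compound 1, with no ranking possible between them on these numbers.

Compound 3 `COc1cc(-n2cnc3ccc(-c4cccc(C)c4)cc32)cc(OC)c1OC` has not yet been measured. It differs from compound 2 in one place, with 3-methylphenyl in place of 4-(trifluoromethyl)phenyl on an aromatic carbon as the counted difference, and the change is 3-methylphenyl in place of 4-(trifluoromethyl)phenyl on an aromatic carbon. Among the compounds with values here, the one step that bears on this is a 1.1-fold higher number from compound 1 to compound 2 (0.04 log units; within the scatter) and it bears only in part, as it concerns trifluoromethyl in place of hydrogen on an aromatic carbon. Within the data shown here, no measured compound carries a methyl group, and the data show nothing direct about the entering group.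

Among the measured compounds shown here, with that small step as the only guide, the change expected in this assay is a 1.1-fold lower number from compound 2 to compound 3 (0.05 log units; within the scatter) and no step beyond the scatter is expected in either direction. Compound 3 is estimated at 3000 nM within an expected range from 1400 nM to 6500 nM in this reading.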

Compound 3, half-maximal inhibitory concentration: 3820 nM
Compound 3: middle estimate off by 1.3-fold (0.10 log units), on the low side, within the range that was stated.
By their numbers in this assay, from the lowest: compounds 1, 2 and 3 (each within the scatter of the next).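

In this assay, going by these compounds alone, compound 3 gives the first reading for methyl on the phenyl ring, and the change from hydrogen, a 1.2-fold higher number from compound 1 to compound 3 (0.10 log units; within the scatter), leaves it level with compound 1. The exchange of groups at this position, a 1.1-fold higher number from compound 2 to compound 3 (0.05 log units; within the scatter), shows that 3-methylphenyl and 4-(trifluoromethyl)phenyl cannot be told apart on these numbers, even though the two groups differ both in the substituent and in where it sits on the phenyl ring, so three different aryl groups on the same aromatic carbon of the shared core now read alike. Nothing available accounts for this flat picture.

All substituents shown on this ring contain only carbon, hydrogen and fluorine, so it remains open whether an amine, a hydroxyl group or a carboxylic acid there would produce a step beyond the scatter. Also open is whether the position tolerates changes more generally, since the phenyl ring is present in every compound shown and a longer alkyl chain in its place would test something these three readings cannot.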